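Varying the Aryl Amine Substituent: Compound 3 to Compound 4

The source may hold more compounds than are shown below. What is called first, only, known or untested is meant among the compounds shown, and "the series" means these compounds.

Of the compounds shown here, three sharing one core have been measured in a functional assay on BT-549 cells (Homo sapiens) for cytotoxicity, read by sulforhodamine B assay, with a stated time of 72 h; a higher number here means a weaker inhibitor, a lower number a stronger inhibitor. Compound 1 `CCS(=O)(=O)Nc1cc(-c2ccc3ncnc(Nc4ccc(F)cc4F)c3c2)cnc1OC` gives 2480 nM, compound 2 `CCS(=O)(=O)Nc1cc(-c2ccc3ncnc(Nc4ccc(OC(F)(F)F)cc4)c3c2)cnc1OC` gives 8240 nM, and compound 3 `CCS(=O)(=O)Nc1cc(-c2ccc3ncnc(Nc4ccc(OC)c(Cl)c4)c3c2)cnc1OC` gives 2470 nM. Compound 3 has the lowest number of the three, but it cannot be separated from compound 1, since a 1.0-fold lower number from compound 1 to compound 3 (0.00 log units; within the scatter). Only compound 2 stands apart, as a 3.3-fold lower number from compound 2 to compound 3 (0.52 log units; beyond the scatter) shows.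

Compound 4 `CCS(=O)(=O)Nc1cc(-c2ccc3ncnc(Nc4ccc(C(=O)OC)c(OC)c4)c3c2)cnc1OC` differs from compound 3 in the same place that was varied among the measured compounds: 3-methoxy-4-(methoxycarbonyl)phenyl in place of 3-chloro-4-methoxyphenyl on a nitrogen on an aromatic ring. Within the data shown here, two steps bear on this position, a 3.3-fold higher number from compound 1 to compound 2 (0.52 log units; beyond the scatter) and a 3.3-fold lower number from compound 2 to compound 3 (0.52 log units; beyond the scatter), both modest, while the third, a 1.0-fold lower number from compound 1 to compound 3 (0.00 log units; within the scatter), stays within the scatter. Exchanges at this position have thus shifted this assay by modest amounts at most. Among the measured compounds shown here, the entering group carries a methoxycarbonyl that no measured compound has, so the direction is uncertain, and the author leans toward a small loss. A step of a 1.6-fold higher number from compound 3 to compound 4 (0.21 log units; within the scatter) is expected. Compound 4 is therefore estimated at 4000 nM in this assay, within a range from 1500 nM to 11000 nM.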

Compound 4, half-maximal inhibitory concentration: 3760 nM
The estimate for compound 4 lay 1.1-fold (0.03 log units) above the measured number; the measured number falls inside the stated range.
By their numbers in this assay, from the lowest: compounds 3, 1 and 4 (each within the scatter of the next); then compound 2.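

In this assay, among these compounds, a methoxycarbonyl on the aryl group at this position, present in none of the earlier compounds, leaves the number close to those of the two lower compounds: the change shows a 1.5-fold higher number from compound 3 to compound 4 (0.18 log units; within the scatter) and a 1.5-fold higher number from compound 1 to compound 4 (0.18 log units; within the scatter), so compound 4 cannot be separated from compound 1 or compound 3. Compound 2 remains the one that stands apart, with a 2.2-fold lower number from compound 2 to compound 4 (0.34 log units; beyond the scatter), which leaves 4-(trifluoromethoxy)phenyl as the only group shown here that sets a compound apart from the others. Nothing at hand accounts for why these different aryl groups fall so close together.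

On these data alone, it remains open whether the methoxycarbonyl itself contributes anything, since compound 4 also carries a methoxy group that differs from those of the other compounds. A carboxylic acid or an amide in its place, or a longer chain on the ester, would bear on that question.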